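Three Esters Measured, a Cyclopropyl Ester Awaited

The source may hold more compounds than are shown below. What is called first, only, known or untested is meant among the compounds shown, and "the series" means these compounds.

Compound 1 `Cc1cn([C@H]2CO[C@@H](COC(=O)C(C)(C)C)O2)c(=O)[nH]c1=O`: in an ADME assay on CCRF-CEM cells (Homo sapiens) for cytotoxicity, read by MTT assay, with a stated time of 3 days (a higher number here means a weaker inhibitor, a lower number a stronger inhibitor), compound 1 gives > 100000 nM, which is a limit of the assay.
Compound 2 `Cc1cn([C@H]2CO[C@@H](COC(=O)C3CCCCC3)O2)c(=O)[nH]c1=O`: in this assay compound 2 gives > 100000 nM, also a limit.
Compound 3 `CC(=O)OC[C@@H]1OC[C@H](n2cc(C)c(=O)[nH]c2=O)O1`: in this assay compound 3 gives 99400 nM.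

Going by the values given here, compound 3 thus holds the only actual number of the three; the other two values are limits. Compound 4 `Cc1cn([C@H]2CO[C@@H](COC(=O)C3CC3)O2)c(=O)[nH]c1=O` differs from compound 3 by cyclopropyl in place of methyl on a carbonyl carbon. The steps that touch the same place are a number no higher from compound 1 to compound 3 (the limit leaves the size open) and a number no higher from compound 2 to compound 3 (the limit leaves the size open); both start at the limit of > 100000 nM in this assay, at which 2 of the 3 values shown sit, so their size cannot be read, and a step that the two limits leave unreadable from compound 1 to compound 2 is likewise unreadable. With every neighbour at or near that limit, no step beyond the scatter is expected in this assay. Compound 4 is therefore expected at 100000 nM, between 50000 nM and 300000 nM. That means an expected step of a 1.0-fold higher number from compound 3 to compound 4 (0.00 log units; within the scatter).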

Compound 4, half-maximal inhibitory concentration: > 100000 nM
Compound 4: no number, only a limit; the forecaster's own chance of this, stated with the estimate: 60%; the middle value lies on the limit itself.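

In this assay compound 4 gives > 100000 nM, which is a limit and not a number, so the cyclopropyl ester adds no measurable value. Swapping methyl for cyclopropyl on this carbonyl carbon gives a number no lower from compound 3 to compound 4 (the limit leaves the size open), and the steps among the esters at the limit cannot be read. Only compound 3 carries a number, and the other esters share one edge of the assay: the limit of > 100000 nM in this assay, at which 3 of the 4 values shown sit.

On these data alone, whether the esters at the limit differ from one another stays open. So does how a longer chain or an amine on this carbonyl carbon would read in this assay.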